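Swapping a hydroxyalkyl chain for a nitrophenyl on the alkyne

This account rests on a few compounds, and the source may have more. Where it says the series, first, only, none or still open, it means among the compounds named here.

Compound 1, `CCC/C=C/C=C/c1cc(C#N)ccc1COC(c1ccc(C#N)cc1)c1cncn1C`, in a functional assay on NIH3T3 cells (Mus musculus) (a lower number here means that less compound is needed, a higher number that more compound is needed for the effect), gives 16.7 nM.
Compound 2, `Cn1cncc1C(OCc1ccc(C#N)cc1C#CCCc1ccccc1)c1ccc(C#N)cc1`, in this assay gives 130 nM.
Compound 3, `Cn1cncc1C(OCc1ccc(C#N)cc1C#CCCCCO)c1ccc(C#N)cc1`, in this assay gives 20.9 nM.

Compound 3 stands second highest of the three numbers: its step of a 1.3-fold higher number from compound 1 to compound 3 (0.10 log units; within the scatter) lies within the scatter, while a 6.2-fold lower number from compound 2 to compound 3 (0.79 log units; beyond the scatter) lies beyond it. Compound 4, `Cn1cncc1C(OCc1ccc(C#N)cc1C#Cc1ccc([N+](=O)[O-])cc1)c1ccc(C#N)cc1`, is compound 3 with 4-nitrophenyl in place of 4-hydroxybutyl on a triple-bonded carbon. For the measured compounds named here, two measured steps bear on this. The step of a 6.2-fold lower number from compound 2 to compound 3 (0.79 log units; beyond the scatter) came from putting 2-hydroxyethyl in place of phenyl on the chain, and the present change runs the opposite way, trading a hydroxyl-bearing chain for an aromatic ring. The step of a 7.8-fold higher number from compound 1 to compound 2 (0.89 log units; beyond the scatter) likewise shows a higher number once a phenyl appears on the side chain. Compound 4 therefore is expected to give a higher number in this assay, with a step of about a 4.3-fold higher number from compound 3 to compound 4 (0.63 log units; beyond the scatter). The nitrophenyl, however, sits on a triple-bonded carbon, a placement not covered by any measured compound, which widens the range. The estimate for compound 4 is 90 nM, expected to lie between 25 nM and 350 nM.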

Compound 4, half-maximal effective concentration: 36 nM
The estimate for compound 4 lay 2.5-fold (0.40 log units) above the measured number; the range from low to high includes it.
By their numbers in this assay, from the lowest: compounds 1, 3 and 4 (each within the scatter of the next, the first and the last beyond it); then compound 2.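

In this assay an aromatic ring can sit directly on the triple-bonded carbon: a 1.7-fold higher number from compound 3 to compound 4 (0.24 log units; within the scatter) is a step that stays within the scatter, so 4-nitrophenyl and 4-hydroxybutyl cannot be told apart here, and compound 4 needs no hydroxyl to stay close to compound 3. An aromatic ring on the side chain therefore does not always bring the high number of compound 2: a 3.6-fold lower number from compound 2 to compound 4 (0.56 log units; beyond the scatter) is a gain from replacing phenethyl with 4-nitrophenyl, although a 2.2-fold higher number from compound 1 to compound 4 (0.33 log units; beyond the scatter) remains a step beyond the scatter when 2-(4-nitrophenyl)ethynyl takes the place of hepta-1,3-dien-1-yl. No measurement is at hand to explain these differences.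

Going by these compounds, what the nitro group itself contributes to the 4-nitrophenyl remains open. So does whether an amine or a carboxylic acid in place of the hydroxyl of the 4-hydroxybutyl, or a longer chain, would keep the number near that of compound 3.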